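An Alkyl Amine in Place of the Cyanophenyl Group

The source may hold more compounds than are shown below. What is called first, only, known or untested is meant among the compounds shown, and "the series" means these compounds.

Measured compounds:
compound 1, `CC(=O)NC[C@H]1CN(c2ccc(OC[C@H](O)CNc3ccccc3)c(F)c2)C(=O)O1`, solubility 296000 nM
compound 2, `CC(=O)NC[C@H]1CN(c2ccc(OC[C@@H](O)CNc3ccc(C#N)cc3)c(F)c2)C(=O)O1`, solubility 47000 nM
compound 3, `CC(=O)NC[C@H]1CN(c2ccc(OC[C@@H](O)CNC3CC3)c(F)c2)C(=O)O1`, solubility 96000000 nM

In a physicochemical assay for solubility, read by HPLC (a higher number here means a more soluble compound, a lower number a less soluble compound), compound 2 gives the lowest of the three numbers; compound 1 stands above it and compound 3 far above both. Compound 4, `CC(=O)NC[C@H]1CN(c2ccc(OC[C@@H](O)CNCCC(C)C)c(F)c2)C(=O)O1`, differs from compound 2 in one place: isopentyl in place of 4-cyanophenyl on an amine nitrogen. For the measured compounds named here, two measured steps bear on this change. a 2000-fold higher number from compound 2 to compound 3 (3.31 log units; beyond the scatter) removes the same aromatic group at the same amine nitrogen, and a 320-fold higher number from compound 1 to compound 3 (2.51 log units; beyond the scatter) runs in the same direction from a closely related aromatic group. A rise of the same kind, though perhaps short of the cyclopropyl case, is expected here, so a large step of a 64-fold higher number from compound 2 to compound 4 (1.81 log units; beyond the scatter) is estimated. Compound 4 is therefore expected to give 3000000 nM, with a range from 400000 nM to 30000000 nM.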

Compound 4, solubility: 385000 nM
The estimate for compound 4 lay 7.8-fold (0.89 log units) above the measured number; the measured number lies below the stated range.
By their numbers in this assay, from the lowest: compound 2; then compounds 1 and 4 (each within the scatter of the next); then compound 3.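

In this assay the removal of the aromatic group does not alone bring the large rise seen with cyclopropyl: an 8.2-fold higher number from compound 2 to compound 4 (0.91 log units; beyond the scatter) is only modest, while a 250-fold lower number from compound 3 to compound 4 (2.40 log units; beyond the scatter) shows that the choice of alkyl group on the amine nitrogen matters greatly. With a 1.3-fold higher number from compound 1 to compound 4 (0.11 log units; within the scatter) the isopentyl compound cannot be told apart from the anilino compound. Nothing measured here explains the gap between isopentyl and cyclopropyl. From the compounds shown here alone, whether a cyclobutyl ring, an ethyl group or a longer chain stands nearer compound 3 or compound 4 remains open.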